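Carbamate tail variation on a shared amino-triazole core

The source may hold more compounds than are shown below. What is called first, only, known or untested is meant among the compounds shown, and "the series" means these compounds.

Measured so far:
compound 1 `COc1cc2ncnc(-n3nc(-c4ccccn4)nc3N)c2cc1OCCCN1CC(C)OC(C)C1` gives 1600 nM
compound 2 `COCCOc1cc2c(-n3nc(-c4ccccn4)nc3N)ncnc2cc1OC` gives 1200 nM
compound 3 `COc1cc2ncnc(-n3nc(-c4ccccn4)nc3N)c2cc1OCCCNC(=O)OC(C)C` gives 1000 nM

In an assay on MCF7 cells for inhibition of Serine-protein kinase ATM (Homo sapiens), read by immunofluorescence, with a stated time of 1 h (a higher number here means a weaker inhibitor, a lower number a stronger inhibitor), the measured compounds sit close together. The step of a 1.3-fold lower number from compound 1 to compound 2 (0.12 log units; within the scatter) and the step of a 1.6-fold lower number from compound 1 to compound 3 (0.20 log units; within the scatter) both stay inside the scatter, and so does the step of a 1.2-fold lower number from compound 2 to compound 3 (0.08 log units; within the scatter). Compound 3 holds the lowest number of the group, yet every gap to its neighbours is of a size that repeated measurements could produce on their own, so no ranking among them can be claimed.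

Compound 4 `COc1cc2ncnc(-n3nc(-c4ccccn4)nc3N)c2cc1OCCCNC(=O)OCC(F)(F)F` is not yet measured. It differs from compound 3 in one place: 2,2,2-trifluoroethyl in place of isopropyl on an oxygen next to a carbonyl group. The carbamate group and the chain that carries it stay as they are.

Within the data shown here, none of the measured steps touches this part of the molecule. The steps from compound 1 to compounds 2 and 3 swap the whole tail, and each left the number within the scatter. Among the measured compounds shown here, there is no step that changes only the carbamate ester, so nothing here points in a direction. The expectation is therefore that compound 4 stays near compound 3, with a step of no change at the digits printed from compound 3 to compound 4 (within the scatter) in this assay. Compound 4 is expected to give about 1000 nM, in a range from 400 nM to 2500 nM.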

Compound 4, half-maximal inhibitory concentration in the Serine-protein kinase ATM assay: 1200 nM
For compound 4 the middle estimate is 1.2-fold (0.08 log units) below the measured one; the measured number falls inside the stated range.
By their numbers in the Serine-protein kinase ATM assay, from the lowest: compounds 3, 2, 4 and 1 (each within the scatter of the next).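

In the Serine-protein kinase ATM assay, the swap of isopropyl for 2,2,2-trifluoroethyl on an oxygen next to a carbonyl group gives a 1.2-fold higher number from compound 3 to compound 4 (0.08 log units; within the scatter). The comparisons that replace the whole tail, no change at the digits printed from compound 2 to compound 4 (within the scatter) and a 1.3-fold lower number from compound 1 to compound 4 (0.12 log units; within the scatter), also stay inside the scatter, so compound 4 cannot be separated from any of the other three on this read-out. The ester end of the carbamate therefore looks free to vary in that assay, but not in a physicochemical assay for solubility, in phosphate buffer, with a stated time of 18 h, at pH 7.4 (on this read-out higher numbers stand for higher solubility and lower numbers for lower solubility), where this one swap moves the number far: the measured solubility of compound 3, 18000 nM, and of compound 4, 100 nM, a 180-fold lower number (2.26 log units; beyond the scatter). In the physicochemical assay compound 3 gives 18000 nM and compound 4 gives 100 nM.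

This single pair cannot tell whether the fall in solubility follows from the fluorine atoms or from the change from isopropyl to a straight two-carbon group, and a plain ethyl on the same oxygen would separate those two readings. From the compounds shown here alone, how a carbamate ester ending in an amine or a carboxylic acid would read in either assay also stays open, as does whether such a group would keep the solubility of compound 3 while the number in the Serine-protein kinase ATM assay holds.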